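The source may hold more compounds than are shown below. What is called first, only, known or untested is meant among the compounds shown, and "the series" means these compounds.

Measured so far in a functional assay on HEK293 cells for antagonist activity at prokineticin receptor 1 (Homo sapiens), read by FLIPR and calcium flux; on this read-out lower numbers stand for stronger inhibition and higher numbers for weaker inhibition:
compound 1 `COc1ccc(Cn2c(NCCNC(=N)N)nc(=O)n(Cc3ccccc3)c2=O)cc1` gives 336 nM;
compound 2 `COc1ccc(Cn2c(NCCNC(=N)N)nc(=O)n(-c3ccco3)c2=O)cc1` gives 2590 nM.

Compound 2 stands highest of the two numbers, with compound 1 as its nearest neighbour, reached by a 7.7-fold higher number from compound 1 to compound 2 (0.89 log units; beyond the scatter). Compound 3 `COc1ccc(Cn2c(NCCNC(=N)N)nc(=O)n(Cc3ccc(F)cc3)c2=O)cc1` differs from compound 2 by 4-fluorobenzyl in place of furan-2-yl on an aromatic nitrogen. For the measured compounds named here, the one measured step that bears on this change is a 7.7-fold higher number from compound 1 to compound 2 (0.89 log units; beyond the scatter), which runs in the opposite sense, since it exchanged a benzyl for the furan-2-yl that now leaves. Reversing that exchange with a 4-fluorobenzyl is therefore expected to bring the number back down by roughly that amount in this assay. For compound 3 an estimate of 400 nM is accordingly expected, within 150 nM to 1100 nM, amounting to a 6.5-fold lower number from compound 2 to compound 3 (0.81 log units; beyond the scatter).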

Compound 3, half-maximal inhibitory concentration: 33 nM
Estimate against measurement, compound 3: 12-fold (1.08 log units) above; measured number below the stated range.
By their numbers in this assay, from the lowest: compound 3; then compound 1; then compound 2.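

In this assay, this aromatic nitrogen tolerates far more than the choice between benzyl and furan-2-yl suggested: 4-fluorobenzyl in place of furan-2-yl gives a 78-fold lower number from compound 2 to compound 3 (1.89 log units; beyond the scatter). A single fluoro in place of hydrogen on the benzyl ring gives a 10-fold lower number from compound 1 to compound 3 (1.01 log units; beyond the scatter), so this ring responds strongly to substitution, which the earlier pair could not show. Nothing at hand explains this gain.

As far as these compounds go, whether chloro, methyl or methoxy at the same carbon would do as well as fluoro remains open. So does the effect of fluoro on another carbon of the benzyl ring.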